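Methyl on a Ring Nitrogen: Expected Outcome on Vero Cells

The compounds below may be only part of what the source reports. "The series", "measured", "known", "first", "only" and "open" are said of these compounds alone.

The measured compounds and their values:
compound 1, `COc1cc(OC)c(-c2nc(N3CCN(C)CC3)nc3ccccc23)c(OC)c1`, gives 50 ug/mL
compound 2, `COc1cc(OC)c(-c2nc(N3CCNCC3)nc3ccccc23)c(OC)c1`, gives 50 ug/mL
compound 3, `Cn1cc(-c2nc(N3CCNCC3)nc3ccccc23)c2ccccc21`, gives 50 ug/mL

Of the compounds shown here, three have so far been tested in an ADME assay on Vero cells (Chlorocebus sabaeus) for antiproliferative activity, read by MTT assay; a lower number here means a stronger inhibitor, a higher number a weaker inhibitor. Compounds 1 and 2 share one core and differ in a single place: from compound 2 to compound 1 the change is methyl in place of hydrogen on an amine nitrogen in a ring, and the step this made is no change at the digits printed from compound 2 to compound 1 (within the scatter). Compound 3 carries a different core; the difference between the two cores is not broken down here. In this assay compound 3 gives 50 ug/mL, which is level with compounds 1 and 2 within the scatter of the measurement.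

Compound 4, `CN1CCN(c2nc(-c3cn(C)c4ccccc34)c3ccccc3n2)CC1`, has not yet been measured. It differs from compound 3 by methyl in place of hydrogen on an amine nitrogen in a ring. This is the same change that was made from compound 2 to compound 1, made here at the same place in the ring. Going by the values given here, because no change at the digits printed from compound 2 to compound 1 (within the scatter) was flat within the scatter, the step of no change at the digits printed from compound 3 to compound 4 (within the scatter) is expected to be flat as well, although only one earlier instance supports this. Compound 4 is therefore estimated to give 50 ug/mL in this assay, with a likely range from 25 ug/mL to 100 ug/mL.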

Compound 4, half-maximal inhibitory concentration: 50 ug/mL
Compound 4: the middle estimate sits on the measured number at the digits printed; low and high end bracket the measured number.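

In this assay, methyl in place of hydrogen on the amine nitrogen of the ring, the change from piperazin-1-yl to 4-methylpiperazin-1-yl, gave no change at the digits printed from compound 3 to compound 4 (within the scatter), and set beside the earlier instance, the step carried from one core to the other without a difference between the two: the same change on two cores in this assay, no change at the digits printed (within the scatter) from compound 2 to compound 1 and no change at the digits printed (within the scatter) from compound 3 to compound 4, 1.0-fold (0.00 log units) apart, within the scatter of two such steps. This shows that in these two matched pairs the core did not alter the outcome of the change, and the step was flat on both. It does not show that the change would be flat on a further core, as the finding rests on two pairs alone, and all four compounds sit level with one another, with compound 4 at 50 ug/mL, so the series offers no case in which the step departs from flat.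

The compounds shown carry only hydrogen or methyl on that ring nitrogen, which leaves open what a longer chain, such as ethyl or propyl, or a chain ending in a carboxylic acid would do at the same place. From the compounds shown here alone, it also remains open whether an open-chain amine in place of piperazin-1-yl would read any differently in this assay.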